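A carboxymethyl swap on a compound at the assay limit

The source may hold more compounds than are shown below. What is called first, only, known or untested is meant among the compounds shown, and "the series" means these compounds.

Of the compounds shown here, two have been measured in a functional assay on FaDu cells (Homo sapiens) for cytotoxicity, read by MTT assay, with a stated time of 72 h (a lower number here means that less compound is tolerated, a higher number that more compound is tolerated), so far. There, compound 1 `COc1ncc(NC(=O)C(=O)c2cn(C(C)C)c3ccccc23)cn1` gives 171 nM as a real number. Compound 2 `COc1ccc(NC(=O)C(=O)c2cn(CC(C)(C)OC)c3ccccc23)cn1` reads > 10000 nM as its result, and this is a limit of the assay and not a number.

Compound 3 `COc1ccc(NC(=O)C(=O)c2cn(CCC(=O)O)c3ccccc23)cn1` keeps the rest of compound 2 and changes one place: carboxymethyl in place of 1-methoxy-1-methylethyl on a saturated chain carbon bound to an aromatic nitrogen describes the swap. In words, carboxymethyl stands in place of 1-methoxy-1-methylethyl on a saturated chain carbon bound to an aromatic nitrogen.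

Among the measured compounds shown here, no measured pair shows what this swap does, so the expectation rests mainly on compound 2 (at > 10000 nM in this assay) as the starting point. I expect no step beyond the usual scatter in this assay and no clear move in either direction, and the assay may again report only a limit. The estimated change is a number no higher from compound 2 to compound 3 (the limit leaves the size open) in this expectation. For compound 3 the expected value is 10000 nM with an estimated range from 2500 nM to 30000 nM in this assay.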

Compound 3, concentration lethal to 50% of the cells: > 10000 nM
Compound 3 ended at the assay's limit (the forecaster's own chance of this, stated with the estimate: 65%); the middle value lies on the limit itself.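

No step can be read from compound 2 to compound 3, because each of the two compounds ends at a limit and not at a number: the limit of > 10000 nM in this assay, at which 2 of the 3 values shown sit.

The compounds shown leave open whether carboxymethyl in place of 1-methoxy-1-methylethyl on a saturated chain carbon bound to an aromatic nitrogen changes the value at all, and in which direction.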